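Amide nitrogen substituents in an imidazolylmethyl benzamide series

The source may hold more compounds than are shown below. What is called first, only, known or untested is meant among the compounds shown, and "the series" means these compounds.

Measured so far:
compound 1 `CCCCNC(=O)[C@@H](NC(=O)c1cccc(Cn2ccnc2)c1)[C@@H](C)CC`: 3%
compound 2 `CCCCS(=O)(=O)NC(=O)[C@@H](NC(=O)c1cccc(Cn2ccnc2)c1)[C@@H](C)CC`: "not determined" (no result reported)
compound 3 `CC[C@H](C)[C@H](NC(=O)c1cccc(Cn2ccnc2)c1)C(=O)NS(=O)(=O)c1ccccc1`: 24%

In an assay on HEK293 cells for displacement of a labelled ligand from Type-2 angiotensin II receptor (Homo sapiens), tested at 10 uM (on this read-out higher numbers stand for a stronger effect at the one concentration tested and lower numbers for a weaker effect), compound 3 gives 24%, the higher of the two numbers available, while compound 1 gives 3%. Compound 2 has no result in this assay. Going by the values given here, the only step that bears on the next change is a number 21 percentage points higher from compound 1 to compound 3 (beyond the scatter), where phenylsulfonyl entered on the amide-type nitrogen. Compound 4 `CC[C@H](C)[C@H](NC(=O)c1cccc(Cn2ccnc2)c1)C(=O)NO` differs from compound 3 as follows: hydroxy in place of phenylsulfonyl on an amide-type nitrogen. The group that accompanied the rise is now removed, so the number is expected to fall back toward that of compound 1 because the whole gain seen in this assay is a number 21 percentage points higher from compound 1 to compound 3 (beyond the scatter). The expected step is a number 16 percentage points lower from compound 3 to compound 4 (beyond the scatter). For compound 4 the estimate is 8%, with a range from 0% to 25%.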

Compound 4, a percentage reported as inhibition, at one concentration (the size of the read-out at that concentration, not a potency): 4%
Beside the measured number, compound 4's estimate is 4 percentage points above it; low and high end bracket the measured number.
By their numbers in this assay, from the lowest: compounds 1 and 4 (each within the scatter of the next); then compound 3.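

In this assay, hydroxy in place of phenylsulfonyl on the amide-type nitrogen gives a number 20 percentage points lower from compound 3 to compound 4 (beyond the scatter), so a second, different replacement of phenylsulfonyl also ends well under compound 3. Hydroxy and butyl cannot be told apart here, with a number 1 percentage points higher from compound 1 to compound 4 (within the scatter), although they differ in chain and size; of the three groups with numbers, only phenylsulfonyl stands apart. No evidence on hand explains this difference.

Open, as far as these compounds go, is whether the step follows the phenyl ring or the sulfonyl unit. A benzyl group and a methanesulfonyl group on this nitrogen would separate the two.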